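The compounds below may be only part of what the source reports. "The series", "measured", "known", "first", "only" and "open" are said of these compounds alone.

Measured in a functional assay on HeLa cells (Homo sapiens) for cytotoxicity, read by XTT assay; a lower number here means that less compound is tolerated, a higher number that more compound is tolerated:
- compound 1 `CC(C)C[C@H](NC(=O)OCc1ccccc1)C(=O)N[C@H](C=O)CCS(C)(=O)=O`: > 224 uM (a limit)
- compound 2 `CSCC[C@@H](C=O)NC(=O)[C@H](CCc1ccccc1)NC(=O)OCc1ccccc1`: 13.5 uM

Among the measured compounds shown here, compound 2, at 13.5 uM, holds the only actual number in this pair. Compound 1 reports only a limit, > 224 uM. Compound 3 `CS(=O)(=O)CC[C@@H](C=O)NC(=O)[C@H](CCc1ccccc1)NC(=O)OCc1ccccc1` departs from compound 2 in one place: methylsulfonyl in place of methylsulfanyl on a saturated chain carbon, three bonds along the chain from an amide-type nitrogen and a carbonyl carbon, with methylsulfonyl in place of methylsulfanyl. For the measured compounds named here, no measured step isolates this change. Going by the values given here, the only hint is that compound 1, which also carries methylsulfonyl, shows > 224 uM. The expected change is a 4.4-fold higher number from compound 2 to compound 3 (0.65 log units; beyond the scatter), toward more compound tolerated and beyond the scatter. For compound 3 the estimated value is 60 uM, with an expected range of 20 uM to 200 uM.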

Compound 3, half-maximal toxic concentration: 162 uM
The estimate for compound 3 lay 2.7-fold (0.43 log units) below the measured number, within the range that was stated.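

Methylsulfonyl in place of methylsulfanyl on this saturated chain carbon now has a measured step of its own in this assay: a 12-fold higher number from compound 2 to compound 3 (1.08 log units; beyond the scatter). With methylsulfonyl kept, benzyl in place of isopropyl gives an at least 1.3-fold lower number from compound 1 to compound 3 (0.14 log units; that floor lies within the scatter), so no order can be read from that step. Compound 1 reports only a limit: the limit of > 224 uM in this assay, at which 1 of the 3 values shown sits.

Going by these compounds, whether methylsulfinyl or a carboxylic acid on the same chain carbon would give a number nearer that of compound 2 or compound 3 stays open. Also open, on these data alone, is how large the methylsulfonyl step would be with isopropyl in place of benzyl.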